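This account rests on a few compounds, and the source may have more. Where it says the series, first, only, none or still open, it means among the compounds named here.

Three compounds of the series have been run in a functional assay for inhibition, with a stated time of 30 min, tested at 1 mM; on this read-out higher numbers stand for more inhibition at the one concentration tested (going by the name of the read-out) and lower numbers for less inhibition. Compound 1 `COc1ccc(/C(Cl)=C/C=C(\C#N)C(=O)c2c[nH]c3ccc(Br)cc23)cc1` gives 15.6% in this assay. Compound 2 `N#C/C(=C\C=C(/Cl)c1ccc(Br)cc1)C(=O)c1c[nH]c2ccccc12` gives 18.4%, and compound 3 `COc1ccc(/C(Cl)=C/C=C(\C#N)C(=O)c2c[nH]c3ccccc23)cc1OC` gives 15.8%. Compound 1 holds the lowest of the three numbers, but the nearest number, that of compound 3, sits only a fraction of a point higher, and even the furthest, that of compound 2, lies within the scatter, so the three measurements cannot be told apart. For the measured compounds named here, no pair among them differs in only one place, so no single step can be read from them. All three read as weak inhibition at the one concentration tested.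

Compound 4 `COc1ccc(/C(Cl)=C/C=C(\C#N)C(=O)c2c[nH]c3ccc(OC)cc23)cc1` has not been measured. It differs from compound 1 in one place: methoxy in place of bromo on an aromatic carbon. Going by the values given here, nothing among the measured compounds isolates this exchange on the shared core, so there is no step to anchor an expectation. With the whole series sitting in a narrow, low band in this assay, compound 4 is expected to stay in that band. The step of a number 0.4 percentage points higher from compound 1 to compound 4 (within the scatter) is estimated to be small and within the scatter, with no direction claimed. The value of compound 4 in this assay is estimated at 16%, in the range 5% to 28%.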

Compound 4, a percentage reported as inhibition, at one concentration (the size of the read-out at that concentration, not a potency): 16.7%
Compound 4: the middle estimate sits 0.7 percentage points below what was measured; the measured number falls inside the stated range.
By their numbers in this assay, from the lowest: compounds 1, 3, 4 and 2 (each within the scatter of the next).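

In this assay, for the compounds shown here, methoxy in place of bromo on this aromatic carbon gives a number 1.1 percentage points higher from compound 1 to compound 4 (within the scatter), the first step that isolates a single change. At this position, meta to a fused ring and para to a fused ring, a single bromine and a methoxy group with its two heavy atoms and one hydrogen-bond acceptor therefore cannot be told apart on this read-out, and the pair stays in the same low band of inhibition at the one concentration tested. No measurement at hand bears on why this exchange leaves the number within the scatter.

Going by these compounds alone, whether an amine, a carboxylic acid or a longer alkoxy chain on this carbon would move the number out of the low band remains open, since bromo and methoxy are the only two groups compared here on the shared core. Also open, going by these compounds, is whether the same exchange would give a similarly small step at another position of the series, as this single pair speaks only for this one carbon.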